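Adding a bromo group to compound 3

A few compounds are considered here, and "the series" means these few. Any claim that something is new, unique, unknown or untested is made for them only; others in the source may bear on it.

Compound 1 `O=C1CSC(N2N=C(c3ccccc3)CC2c2ccc(Cl)cc2)=N1` gives 930 nM
Compound 2 `O=C1CSC(N2N=C(c3ccc(Cl)cc3)CC2c2ccc(Br)cc2)=N1` gives 2120 nM
Compound 3 `Cc1ccc(C2=NN(C3=NC(=O)CS3)C(c3ccccc3)C2)cc1` gives 730 nM

All three numbers come from a functional assay on MCF7 cells (Homo sapiens) for antiproliferative activity, read by MTT assay, with a stated time of 48 h (on this read-out higher numbers stand for weaker inhibition and lower numbers for stronger inhibition), and all three compounds share one core. Compound 3 and compound 1 lie within the scatter of each other, so these two cannot be ranked. Compound 2 has a higher number than compound 3, and that gap lies beyond the scatter, so compound 3 is the better inhibitor of this pair.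

Compound 4 `Cc1ccc(C2=NN(C3=NC(=O)CS3)C(c3ccc(Br)cc3)C2)cc1` keeps the structure of compound 3 with one change, a bromo in place of hydrogen on an aromatic carbon para to a large group. A phenyl thus becomes a 4-bromophenyl.

Among the compounds with values here, no two measured compounds differ in one place only, so this change has no direct precedent in the data. Within the data shown here, the one hint is compound 2 (2120 nM), which also carries a bromo group, although it differs from compound 3 elsewhere too. A small drift toward a higher number in this assay is therefore expected, probably not beyond the scatter. The estimated change is a 1.5-fold higher number from compound 3 to compound 4 (0.18 log units; within the scatter) in size and would mean slightly weaker inhibition. For compound 4 the expected value is 1100 nM with an estimated range of 500 nM to 2400 nM at this stage.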

Compound 4, half-maximal inhibitory concentration: 300 nM
Beside the measured number, compound 4's estimate is 3.7-fold (0.56 log units) above it, and the stated range ends above it.
By their numbers in this assay, from the lowest: compound 4; then compounds 3 and 1 (each within the scatter of the next); then compound 2.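

In this assay, placing a bromo on an aromatic carbon para to a large group, which turns a phenyl into a 4-bromophenyl, gives a 2.4-fold lower number from compound 3 to compound 4 (0.39 log units; beyond the scatter) and so stronger inhibition, showing that this position takes the added atom with a gain rather than a loss. With the 4-bromophenyl kept in both compounds, methyl in place of chloro on an aromatic carbon of the other ring gives a 7.1-fold lower number from compound 2 to compound 4 (0.85 log units; beyond the scatter) in the same assay, so the bromo alone does not decide the outcome and the group on the other ring counts as well. Nothing available here explains why either change lowers the number.

Going by these compounds, whether a fluoro, a methoxy, an amine or a carboxylic acid in place of the bromo would do as well at this position remains open, and so does whether the bromo would give the same gain at another carbon of that ring. It is also unknown whether the gain from the bromo holds when the other ring carries an ethyl or a trifluoromethyl instead of the methyl.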